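Swapping the aryl group on a sulfonyl: compound 4

A few compounds are considered here, and "the series" means these few. Any claim that something is new, unique, unknown or untested is made for them only; others in the source may bear on it.

Of the compounds shown here, three sharing one core have been tested in a functional assay on Jurkat cells (Homo sapiens) for antiproliferative activity, read by MTT assay and trypan blue exclusion, with a stated time of 72 h; on this read-out lower numbers stand for stronger inhibition and higher numbers for weaker inhibition. Compound 1 `COC(=O)c1ccc(C2SCC(=O)N2c2ccc(N3CCN(Cc4cc(OC)c(OC)c(OC)c4)CC3)cn2)c(OC)c1` gives 41000 nM, compound 2 `COC(=O)c1ccc(C2SCC(=O)N2c2ccc(N3CCN(Cc4cccc([N+](=O)[O-])c4)CC3)cn2)c(OC)c1` gives 37400 nM, and compound 3 `COC(=O)c1ccc(C2SCC(=O)N2c2ccc(N3CCN(S(=O)(=O)c4ccc(F)cc4)CC3)cn2)c(OC)c1` gives 78300 nM. Compound 3 has the highest number of the three: compared with compound 2 the step was a 2.1-fold higher number from compound 2 to compound 3 (0.32 log units; beyond the scatter), while its gap to compound 1 lies within the scatter, so no order between compound 3 and compound 1 can be read.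

Compound 4 `COC(=O)c1ccc(C2SCC(=O)N2c2ccc(N3CCN(S(=O)(=O)c4cc(Cl)ccc4Cl)CC3)cn2)c(OC)c1` differs from compound 3 by 2,5-dichlorophenyl in place of 4-fluorophenyl on a sulfonyl sulfur. Going by the values given here, no measured step changes an aryl group on a sulfonyl sulfur. Among the compounds with values here, the closest comparison is an aryl exchange on a ring nitrogen's chain carbon, a 1.1-fold lower number from compound 1 to compound 2 (0.04 log units; within the scatter), which was within the scatter; the only step beyond the scatter, a 2.1-fold higher number from compound 2 to compound 3 (0.32 log units; beyond the scatter), changed a different part. For compound 4 a step of about a 1.1-fold lower number from compound 3 to compound 4 (0.05 log units; within the scatter) is therefore expected, essentially none beyond the scatter. Compound 4 is estimated at 70000 nM, within a range from 30000 nM to 160000 nM.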

Compound 4, half-maximal inhibitory concentration: > 100000 nM
Compound 4 was reported as a limit; the forecaster's own chance of this, stated with the estimate: 15%; at least 1.4-fold (0.15 log units) between middle value and limit.
By their numbers in this assay, from the lowest: compounds 2, 1 and 3 (each within the scatter of the next, the first and the last beyond it). At a limit, above all of these: compound 4.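

In this assay, compound 4 is known only as a limit, not as a number: the limit of > 100000 nM in this assay, at which 1 of the 4 values shown sits. Going by these compounds alone, this is the first change to the aryl group on the sulfonyl sulfur, but the step, an at least 1.2-fold higher number from compound 3 to compound 4 (0.10 log units; that floor lies within the scatter), has a floor within the scatter, so it shows neither how much the swap to 2,5-dichlorophenyl costs nor that it costs anything at all. The step of an at least 2.6-fold higher number from compound 2 to compound 4 (0.42 log units; beyond the scatter) is beyond the scatter, so with (2,5-dichlorophenyl)sulfonyl on the amine nitrogen in the ring, inhibition is weaker than with 3-nitrobenzyl there.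

Going by these compounds, the true size of the difference between the two aryl groups on the sulfonyl stays open. So does whether a plain phenyl, a methyl on the sulfonyl sulfur, or a carbonyl in place of the sulfonyl would give stronger inhibition.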